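A few compounds are considered here, and "the series" means these few. Any claim that something is new, unique, unknown or untested is made for them only; others in the source may bear on it.

Measured so far:
compound 1 `Cc1nccn1-c1cnc(NCc2c(F)ccc3c2CCO3)c2cn[nH]c(=O)c12` — 7000 nM
compound 2 `CN(C)Cc1ccc(C(=O)Nc2cnc(NCc3c(F)ccc4c3CCO4)n3cnnc23)cc1` — 520000 nM

In a physicochemical assay for solubility, read by LC-MS, in phosphate buffer, with a stated time of 24 h, at pH 7.4 (on this read-out lower numbers stand for lower solubility and higher numbers for higher solubility), compound 1 gives 7000 nM, the lowest of the two numbers, while compound 2 gives 520000 nM, a gap well beyond the scatter. Among the compounds with values here, no pair differing in a single place has been measured, so no step is known. Compound 3 `CNC(=O)c1ncc(-c2cnc(NCc3c(F)ccc4c3CCO4)c3cn[nH]c(=O)c23)n1C` differs from compound 1 in one place: 1-methyl-2-(methylcarbamoyl)-1H-imidazol-5-yl in place of 2-methyl-1H-imidazol-1-yl on an aromatic carbon. The expected step is a modest rise, a 2.1-fold higher number from compound 1 to compound 3 (0.33 log units; beyond the scatter), possibly still inside the scatter. Compound 3 is estimated at 15000 nM, within 4000 nM to 60000 nM.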

Compound 3, solubility: 5000 nM
Beside the measured number, compound 3's estimate is 3.0-fold (0.48 log units) above it, within the range that was stated.
By their numbers in this assay, from the lowest: compounds 3 and 1 (each within the scatter of the next); then compound 2.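

On this aromatic carbon, para to a large group, the exchange of 2-methyl-1H-imidazol-1-yl for 1-methyl-2-(methylcarbamoyl)-1H-imidazol-5-yl gives the first step known in this assay: a 1.4-fold lower number from compound 1 to compound 3 (0.15 log units; within the scatter). The position therefore takes the larger group, with its hydrogen-bond donor, without a change beyond the scatter. No measurement shown accounts for this result. From the compounds shown here alone, whether an amine or a carboxylic acid in place of the methylcarbamoyl group would shift the number beyond the scatter remains open, as does the effect of a longer chain there.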